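The source may report more compounds than this note shows. Statements on the series, on what has been measured and on what is new or still open speak of the compounds shown alone.

Values so far in a functional assay on HT-29 cells (Homo sapiens) for cytotoxicity, read by MTT assay, with a stated time of 24 h; a lower number here means a stronger inhibitor, a higher number a weaker inhibitor
compound 1 `Cn1cnnc1SCC(=O)Nc1ccc(-c2nc(-c3ccccc3)c(-c3ccccc3)n2C)cc1` gives 10.7 ug/mL
compound 2 `Cc1nnc(SCC(=O)Nc2ccc(-c3nc(-c4ccccc4)c(-c4ccccc4)n3C)cc2)s1` gives 2.7 ug/mL
compound 3 `CN1CCN(CC(=O)Nc2ccc(-c3nc(-c4ccccc4)c(-c4ccccc4)n3C)cc2)CC1` gives 35.5 ug/mL

Compound 3 has the highest number of the three and is the weakest inhibitor among them. The steps up to it are a 3.3-fold higher number from compound 1 to compound 3 (0.52 log units; beyond the scatter) and a 13-fold higher number from compound 2 to compound 3 (1.12 log units; beyond the scatter) and both lie beyond the scatter.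

Compound 4 `Cc1ccc(CN2CCN(CC(=O)Nc3ccc(-c4nc(-c5ccccc5)c(-c5ccccc5)n4C)cc3)CC2)cc1` differs from compound 3 in one place, and that difference is 4-methylphenyl in place of hydrogen on a saturated chain carbon bound to an amine nitrogen in a ring in all: 4-methylphenyl in place of hydrogen on a saturated chain carbon bound to an amine nitrogen in a ring. Read one bond further out, this is methyl to 4-methylbenzyl.

Going by the values given here, no measured step changes this place, so the evidence is indirect. The nearest steps exchange the whole group on the saturated chain carbon bound to a carbonyl carbon, and they show that this part of the molecule can shift the number. Those steps are modest in a 3.3-fold higher number from compound 1 to compound 3 (0.52 log units; beyond the scatter) and large in a 13-fold higher number from compound 2 to compound 3 (1.12 log units; beyond the scatter) while a sulfur-linked exchange gives a 4.0-fold lower number from compound 1 to compound 2 (0.60 log units; beyond the scatter) for comparison. None of them adds a 4-methylphenyl, so the direction is tentative.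

A modest step towards a lower number is expected in this assay with no change beyond the scatter remaining possible. The expected step is a 2.4-fold lower number from compound 3 to compound 4 (0.37 log units; beyond the scatter) on this estimate. Compound 4 is estimated at 15 ug/mL with an expected range from 5 ug/mL to 45 ug/mL in this test.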

Compound 4, half-maximal inhibitory concentration: 62 ug/mL
Beside the measured number, compound 4's estimate is 4.1-fold (0.62 log units) below it; measured number above the stated range.
By their numbers in this assay, from the lowest: compound 2; then compound 1; then compounds 3 and 4 (each within the scatter of the next).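

Going by these compounds alone, this is the first direct reading of the saturated chain carbon bound to an amine nitrogen in a ring: in this assay, putting 4-methylphenyl in place of hydrogen there, which turns methyl into 4-methylbenzyl, gives a 1.7-fold higher number from compound 3 to compound 4 (0.24 log units; within the scatter). The six-membered aromatic ring of carbon thus enters at this place with no change that stands clear of the scatter, whereas the earlier exchange of the whole group on the saturated chain carbon bound to a carbonyl carbon gave a 13-fold higher number from compound 2 to compound 3 (1.12 log units; beyond the scatter). The data shown offer no measurement that would explain this outcome.

As far as these compounds go, this single step covers one group only, so it remains open whether a carboxylic acid or an amine in place of the methyl on the 4-methylphenyl would also leave the number within the scatter of compound 3. From the compounds shown here alone, it is equally open whether a longer chain in place of the methyl of compound 3 would read the same in this assay, or whether only the exchange of the whole group moves the number.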